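Adding a Phenyl Ring to a Pyrrole Benzylamide

The compounds below may be only part of what the source reports. "The series", "measured", "known", "first", "only" and "open" are said of these compounds alone.

Compound 1 `O=C(NCc1ccccc1)c1cc(Br)c(Br)[nH]1`: > 50000 nM
Compound 2 `O=C(NCc1ccc(Cl)c(Cl)c1)c1cc(Br)c(Br)[nH]1`: 27000 nM

In a functional assay on U-87MG ATCC cells (Homo sapiens) for inhibition, read by MTT assay, with a stated time of 72 h (a higher number here means a weaker inhibitor of growth, a lower number a stronger inhibitor of growth), compound 1 gives > 50000 nM, which is a limit of the assay rather than a number. Compound 1 sits at the limit of > 50000 nM in this assay, at which 1 of the 2 values shown sits. In this assay compound 2 gives 27000 nM. Compound 3 `O=C(NCc1ccc(-c2ccccc2)cc1)c1cc(Br)c(Br)[nH]1` differs from compound 1 by phenyl in place of hydrogen on an aromatic carbon. Among the measured compounds shown here, no step between measured compounds is available, so the change is expected to bring a moderate move toward stronger inhibition, an at least 3.3-fold lower number from compound 1 to compound 3 (0.52 log units; beyond the scatter). Compound 3 is estimated to give 15000 nM, expected between 4000 nM and 60000 nM.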

Compound 3, concentration for 50% growth inhibition: > 50000 nM
Compound 3 gave a limit, no number; the forecaster's own chance of this, stated with the estimate: 30%; middle value at least 3.3-fold (0.52 log units) away from the limit.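

Compound 1 and compound 3 both stop at a limit of the assay, so no step between them can be read: the limit of > 50000 nM in this assay, at which 2 of the 3 values shown sit.

The compounds shown leave open whether the added phenyl changes growth inhibition at all, and in which direction.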